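Dithiocarbamate triazoles on gastric cancer cells: an open step

This account rests on a few compounds, and the source may have more. Where it says the series, first, only, none or still open, it means among the compounds named here.

Measured so far:
- compound 1, `Fc1ccccc1Cn1cc(CSC(=S)N2CCNCC2)nn1`: 19400 nM
- compound 2, `COc1ccc(Cn2cc(CSC(=S)N3CCNCC3)nn2)cc1`: no result reported

Compound 1, `Fc1ccccc1Cn1cc(CSC(=S)N2CCNCC2)nn1`, was tested in a functional assay on MGC-803 cells (Homo sapiens) for inhibition, read by MTT assay, with a stated time of 72 h (a lower number here means a stronger inhibitor, a higher number a weaker inhibitor), and gave 19400 nM. Compound 2, `COc1ccc(Cn2cc(CSC(=S)N3CCNCC3)nn2)cc1`, shares the same core but in this assay is recorded only as "not determined" (no result reported), so nothing can be said of where it stands beyond the fact that no value exists for it. The next compound is compound 3, `S=C(SCc1cn(Cc2ccccc2Cl)nn1)N1CCNCC1`. Its change from compound 2 is 2-chlorophenyl in place of 4-methoxyphenyl on a saturated chain carbon bound to an aromatic nitrogen. Among the measured compounds shown here, with no measured step between these two and no value for compound 2, the direction of the step is unknown; a modest change, not far beyond the usual scatter, seems most likely. Taking compound 1 as the only anchor, the estimate for compound 3 in this assay is 15000 nM, expected to fall between 5000 nM and 50000 nM.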

Compound 3, half-maximal inhibitory concentration: 45200 nM
The estimate for compound 3 lay 3.0-fold (0.48 log units) below the measured number; measured number inside the range.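

Compound 3 gives the series its first readable step: in this assay, chloro in place of fluoro on an aromatic carbon produces a 2.3-fold higher number from compound 1 to compound 3 (0.37 log units; beyond the scatter) and so a weaker inhibitor. The earlier compounds shown here could not show that this one exchange moves the result beyond the usual scatter, since only compound 1 carried a number. It remains a single step between two compounds, so it sets no trend, and nothing available explains the loss.

As far as these compounds go, the step from compound 2 to compound 3 cannot be read, since compound 2 has no value, and so the place of 4-methoxyphenyl relative to 2-chlorophenyl stays unknown. Also open, from the compounds shown here alone, is whether bromo or trifluoromethyl on that aromatic carbon would weaken inhibition further or restore it.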